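Lengthening the chain of compound 1

The source may report more compounds than this note shows. Statements on the series, on what has been measured and on what is new or still open speak of the compounds shown alone.

Compound 1 `CCCCCCCCCCCNC[C@@H]1OC[C@H](N)[C@@H]1O` gives 19300 nM as measured
Compound 2 `CCCCCCCCCCCNC[C@@H]1OC[C@H](N)[C@H]1O` gives 88800 nM as measured
Compound 3 `CCCCCCCCCCCCCCNC[C@@H]1OC[C@H](N)[C@@H]1O` awaits measurement

Compound 1 holds the lower of the two numbers in a functional assay on B16-F10 cells (Mus musculus) for antiproliferative activity, read by MTT assay, with a stated time of 72 h (a higher number here means a weaker inhibitor, a lower number a stronger inhibitor), and its nearest neighbour lies at a 4.6-fold higher number from compound 1 to compound 2 (0.66 log units; beyond the scatter) in a modest step that goes with the fact that compounds 1 and 2 differ only in the configuration as drawn in this pair. For the measured compounds named here, compound 3 keeps the core of compound 1 and carries propyl in place of hydrogen on a saturated chain carbon, ten or more bonds along the chain from an amine nitrogen as its only change. Going by the values given here, no measured step touches the chain, so the step to compound 2 at a 4.6-fold higher number from compound 1 to compound 2 (0.66 log units; beyond the scatter) serves only as a gauge of size. A similarly modest step is expected in this assay with a tentative lean towards a lower number. The estimated move is a 1.9-fold lower number from compound 1 to compound 3 (0.29 log units; within the scatter) on this reading. For compound 3 the expected value is 10000 nM with an estimated range from 3000 nM to 35000 nM in this assay overall.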

Compound 3, half-maximal inhibitory concentration: 14300 nM
Estimate against measurement, compound 3: 1.4-fold (0.16 log units) below, within the range that was stated.
By their numbers in this assay, from the lowest: compounds 3 and 1 (each within the scatter of the next); then compound 2.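

The chain of compound 1 proves tolerant of this change in this assay: propyl in place of hydrogen on a saturated chain carbon, ten or more bonds along the chain from an amine nitrogen, gives a 1.3-fold lower number from compound 1 to compound 3 (0.13 log units; within the scatter). For the compounds shown here, until now the only measured step was one of configuration at a saturated ring carbon, a 4.6-fold higher number from compound 1 to compound 2 (0.66 log units; beyond the scatter), and that step lies beyond the scatter, whereas this first step on the chain does not. Nothing available bears on why the chain change reads this way.

Going by these compounds, whether a shorter chain than that of compound 1, or a longer chain than that of compound 3, would move the number beyond the scatter remains open. So does whether the same lengthening would read alike with the configuration of compound 2.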